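A few compounds are considered here, and "the series" means these few. Any claim that something is new, unique, unknown or untested is made for them only; others in the source may bear on it.

Working notes on the series

Compound 1 `COc1cc(N(Cc2nc3ccccc3[nH]2)S(=O)(=O)c2ccc(C)cc2)cc(OC)c1OC` is the reference point: in a functional assay on MCF7 cells (Homo sapiens) for inhibition, read by MTT assay, with a stated time of 48 h (on this read-out lower numbers stand for stronger inhibition and higher numbers for weaker inhibition), compound 1 gives 5400 nM. Compound 2 `COc1cc(N(Cc2nc3ccccc3[nH]2)S(=O)(=O)c2ccc(C(C)(C)C)cc2)cc(OC)c1OC` carries the change tert-butyl in place of methyl on an aromatic carbon and gives 33600 nM, the step being a 6.2-fold higher number from compound 1 to compound 2 (0.79 log units; beyond the scatter). Compound 3 `COc1cc(N(Cc2nc3ccccc3[nH]2)C(=O)c2ccc(C)cc2)cc(OC)c1OC` differs from compound 1 in its core by (4-methylphenyl)carbonyl in place of (4-methylphenyl)sulfonyl on a nitrogen on an aromatic ring; in this assay compound 3 gives 49300 nM, and the step is a 9.1-fold higher number from compound 1 to compound 3 (0.96 log units; beyond the scatter). The numbers of compound 2 and compound 3 sit within the scatter of one another, so no order between them is read.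

Compound 4 `COc1cc(N(Cc2nc3ccccc3[nH]2)C(=O)c2ccc(C(C)(C)C)cc2)cc(OC)c1OC` is not yet measured. It stands to compound 3 as compound 2 stands to compound 1: the change is tert-butyl in place of methyl on an aromatic carbon, made at the same place, and it occurs twice among these compounds. Going by the values given here, the only measured instance is a 6.2-fold higher number from compound 1 to compound 2 (0.79 log units; beyond the scatter), made on the core of compound 1; whether it carries over to the core of compound 3 is untested. Taking that single step as the guide, the expected step is a 4.1-fold higher number from compound 3 to compound 4 (0.61 log units; beyond the scatter), resting on compound 1 and the step of a 6.2-fold higher number from compound 1 to compound 2 (0.79 log units; beyond the scatter). Compound 4 is therefore expected to give about 200000 nM, in a range from 60000 nM to 600000 nM, with a real chance that this assay returns only a limit.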

Compound 4, half-maximal inhibitory concentration: 48800 nM
Beside the measured number, compound 4's estimate is 4.1-fold (0.61 log units) above it; the measured number lies below the stated range.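

In this assay the step on the core of compound 3 reads a 1.0-fold lower number from compound 3 to compound 4 (0.00 log units; within the scatter), so tert-butyl in place of methyl shows no measurable effect on that core. The change therefore does not carry over unaltered from the core of compound 1 to the core of compound 3, and the two instances differ: the same change on two cores in this assay, a 6.2-fold higher number (0.79 log units; beyond the scatter) from compound 1 to compound 2 and a 1.0-fold lower number (0.00 log units; within the scatter) from compound 3 to compound 4, 6.3-fold (0.80 log units) apart, beyond the scatter of two such steps. This rests on one pair per core in a single assay, so it does not show what sets the two cores apart or how the change would read on any further core.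

The compounds shown leave open how a group other than methyl or tert-butyl at the same place, such as an amine, a carboxylic acid or a methoxy group, would read on each of the two cores. They also leave open whether the difference between the two steps would appear in a read-out on another cell line.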